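Chain shortening in the carbonyl series of phenol compounds

The source may hold more compounds than are shown below. What is called first, only, known or untested is meant among the compounds shown, and "the series" means these compounds.

Measured so far in this assay:
compound 1 `CCCCCCCCCCCCNc1ccc(O)cc1`: 82%
compound 2 `CCCCCCCCCCNc1ccc(O)cc1`: 82%
compound 3 `CCCCCCCCCCCC(=O)Nc1ccc(O)cc1`: 23%

In a functional assay on HuCCT-1 cells (Homo sapiens) for inhibition, read by MTT assay, with a stated time of 72 h, tested at 4 uM (on this read-out lower numbers stand for less inhibition of growth and higher numbers for more inhibition of growth at the one concentration tested), compound 1 gives 82% and compound 2 gives 82%. Compound 3 gives 23%, the lowest of the three numbers, set apart from compound 1 and from compound 2 by a gap beyond the scatter in each case. For the measured compounds named here, no single-place step is recorded between compound 3 and either of the other two, so only the values themselves can be set side by side; the carbonyl-bearing chain of compound 3 goes with the low number.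

Compound 4 `CCCCCCCCCC(=O)Nc1ccc(O)cc1` is the next member and has not been measured. It differs from compound 3 as follows: hydrogen in place of ethyl on a saturated chain carbon, nine bonds along the chain from a carbonyl carbon. Going by the values given here, the one measured step that bears on this change is no change at the digits printed from compound 1 to compound 2 (within the scatter), the same shortening of a saturated chain carried out on the pair without the carbonyl; that step stayed within the scatter. The change is therefore expected to leave the read-out of compound 3 essentially where it is, with no step beyond the scatter, as no change at the digits printed from compound 3 to compound 4 (within the scatter).

Compound 4 is expected to give 23%, within a range from 8% to 40%.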

Compound 4, percent growth inhibition at one concentration: 23%
The estimate for compound 4 equals the measured number at the digits printed; low and high end bracket the measured number.
By their numbers in this assay, from the lowest: compounds 3 and 4 (each within the scatter of the next); then compounds 1 and 2 (each within the scatter of the next).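

In this assay, for the compounds shown here, the step on the carbonyl series reads no change at the digits printed from compound 3 to compound 4 (within the scatter) and is the first reading of this change at this place: hydrogen in place of ethyl on a saturated chain carbon, nine bonds along the chain from a carbonyl carbon. Going by these compounds alone, until now, the only reading of this shortening came from the pair without the carbonyl, so it could have been specific to that core. That reading no longer stands alone, as the shortening now leaves the number in place on both cores: the same change on two cores in this assay, no change at the digits printed (within the scatter) from compound 1 to compound 2 and no change at the digits printed (within the scatter) from compound 3 to compound 4, 0 percentage points apart, within the scatter of two such steps.

Within the data shown here, for the carbonyl series, the notes cover only the pair of compound 3 and compound 4, so a chain shorter than that of compound 4 remains open, as does the length at which shortening would begin to move the number in this assay on this core. Also open, as far as these compounds go, is whether a longer chain, or an amine or a carboxylic acid at the far end of the chain of compound 4, would leave the read-out where it stands.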